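Fluoro substitution in the piperidinyl-amide series: a second placement

A few compounds are considered here, and "the series" means these few. Any claim that something is new, unique, unknown or untested is made for them only; others in the source may bear on it.

Compound 1 `O=C(Nc1ccc(Cl)cc1)C1=CCN(c2ncccc2Cl)CC1` and compound 2 `O=C(Nc1ccc(Cl)cc1F)C1=CCN(c2ncccc2Cl)CC1` differ only in fluoro in place of hydrogen on an aromatic carbon. In an in vitro functional assay on 1321-N1 cells for antagonist activity at transient receptor potential cation channel subfamily V member 1 (Homo sapiens), read by FLIPR and calcium flux (on this read-out lower numbers stand for stronger inhibition and higher numbers for weaker inhibition), compound 1 gives 33 nM, while compound 2 gives 618 nM, so the step of a 19-fold higher number from compound 1 to compound 2 (1.27 log units; beyond the scatter) marks a clear loss.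

Compound 3 `CC(C)(C)c1ccc(NC(=O)C2=CCN(c3ccccn3)CC2)cc1` carries a different core; how it differs from compound 1 is not broken down here. In this assay compound 3 gives 27 nM, close to the value of compound 1 and well apart from that of compound 2.

Compound 4 `CC(C)(C)c1ccc(NC(=O)C2=CCN(c3ncccc3F)CC2)cc1` is obtained from compound 3 by fluoro in place of hydrogen on an aromatic carbon. Within the data shown here, this is the same kind of change as the one from compound 1 to compound 2, not the same: there the fluoro entered a six-membered aromatic ring of carbon only, meta to a chloro group, whereas here it enters a six-membered aromatic ring with one nitrogen, two atoms from the ring nitrogen. The large step seen earlier therefore need not carry over, and compound 1, which bears a chloro on the corresponding ring and gives 33 nM, suggests a substituent there is tolerated. For compound 4 a small step of about a 1.1-fold higher number from compound 3 to compound 4 (0.05 log units; within the scatter) is expected, giving an estimated 30 nM in this assay, with a likely range of 12 nM to 90 nM.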

Compound 4, half-maximal inhibitory concentration: 19 nM
Estimate against measurement, compound 4: 1.6-fold (0.20 log units) above, and the stated range covers the measured number.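

In this assay, pyridin-2-yl to 3-fluoropyridin-2-yl gives a 1.4-fold lower number from compound 3 to compound 4 (0.15 log units; within the scatter), so this placement of fluoro leaves the read-out unchanged within the scatter. Fluoro in place of hydrogen on an aromatic carbon therefore does not carry a single size of step from one core to another in this series: the same change on two cores in this assay, a 19-fold higher number (1.27 log units; beyond the scatter) from compound 1 to compound 2 and a 1.4-fold lower number (0.15 log units; within the scatter) from compound 3 to compound 4, 27-fold (1.43 log units) apart, beyond the scatter of two such steps. These two pairs do not show what separates the steps: the fluoro enters a different ring in each pair and the cores differ elsewhere too, so neither the ring nor the rest of the core can be singled out, and no rule for other cores follows.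

The compounds shown leave open whether fluoro on the six-membered aromatic ring of carbon only in compound 3 would repeat the large step, a 19-fold higher number from compound 1 to compound 2 (1.27 log units; beyond the scatter). They also leave open how a methoxy group or a nitrile would read in place of the fluoro of compound 4.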